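Swapping a Ring Hydrogen for Chloro: Expected Cytotoxicity

The source may hold more compounds than are shown below. What is called first, only, known or untested is meant among the compounds shown, and "the series" means these compounds.

Three compounds share one core and differ only in the group on the six-membered aromatic ring of carbon only. Compound 1 `N=c1c(=O)[nH]nc2n1CCN2c1ccccc1Cl` gives 0% in an ADME assay on Vero cells (Chlorocebus sabaeus) for cytotoxicity, with a stated time of 72 h, tested at 10 ug/mL; on this read-out lower numbers stand for a weaker effect and higher numbers for a stronger effect at the one concentration tested. Compound 2 `Cc1ccc(N2CCn3c2n[nH]c(=O)c3=N)cc1` gives 0% in this assay. Compound 3 `N=c1c(=O)[nH]nc2n1CCN2c1ccccc1` gives 26% in this assay, the highest of the three numbers, with compound 1 and compound 2 each sitting beyond the scatter below it.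

The step to compound 4 `N=c1c(=O)[nH]nc2n1CCN2c1ccc(Cl)cc1` is chloro in place of hydrogen on an aromatic carbon.

Within the data shown here, two measured steps bear on this. The change a number 26 percentage points higher from compound 1 to compound 3 (beyond the scatter) is the reverse of adding chloro, though at a different place on the ring. The change a number 26 percentage points higher from compound 2 to compound 3 (beyond the scatter) shows that a methyl entering at the place para to a large group also ends at the bottom. Both point the same way: any group entering this ring brought the number down by a modest amount, and compound 4 is therefore expected to follow, with a number 23 percentage points lower from compound 3 to compound 4 (beyond the scatter) as the estimated step. Compound 4 is expected to give 3% in this assay, within a range from 0% to 20%.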

Compound 4, a percentage reported as inhibition, at one concentration (the size of the read-out at that concentration, not a potency): 0%
Estimate against measurement, compound 4: 3 percentage points above, and the stated range covers the measured number.
By their numbers in this assay, from the lowest: compounds 1, 2 and 4 (each within the scatter of the next); then compound 3.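

Chloro on an aromatic carbon para to a large group now has a direct measurement: in this assay, the change gives a number 26 percentage points lower from compound 3 to compound 4 (beyond the scatter), whereas the earlier chloro comparison concerned a different place on the ring. Chloro in place of methyl at this same place gives no change at the digits printed from compound 2 to compound 4 (within the scatter), so the two groups cannot be told apart here, and compound 3, with hydrogen on this carbon, remains the one compound that stands out from the others. No available evidence explains why either group gives a lower number than hydrogen.

An amine or a carboxylic acid at this place might match compound 3, or might instead match compound 2 and compound 4. Every substituted compound shown here reads at the bottom of the scale. The compounds shown also cannot rank chloro against methyl in any finer way.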